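A few compounds are considered here, and "the series" means these few. Any claim that something is new, unique, unknown or untested is made for them only; others in the source may bear on it.

Compound 1 `Cn1nc(Cc2ccccc2)c2ccccc2c1=O`: <= 10000 nM
Compound 2 `COc1ccc(Cc2nn(C(C)(C)C)c(=O)c3ccccc23)cc1OC`: 10000 nM
Compound 3 `CCn1nc(Cc2ccc(OC)cc2)c2ccccc2c1=O`: "not determined" (no result reported)

Of the compounds shown here, three sharing one core have been tested in a functional assay on aorta with Alpha-1D adrenergic receptor (Rattus norvegicus) as the target; a lower number here means that less compound is needed, a higher number that more compound is needed for the effect. Compound 1 stands at a limit of the assay rather than a number, <= 10000 nM, which the data record as the limit of <= 10000 nM in this assay, at which 1 of the 3 values shown sits. In this assay compound 2 gives 10000 nM. For compound 3 the result in this assay is "not determined" (no result reported). Within the data shown here, no step between two measured compounds is available, so the size of any change remains untested.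

Compound 4 `Cn1nc(Cc2ccc(Cl)cc2)c2ccccc2c1=O` differs from compound 1 in one place: chloro in place of hydrogen on an aromatic carbon. Among the measured compounds shown here, with no measured step to lean on, the expected step from compound 1 to compound 4 in this assay is none beyond the scatter, a number no lower from compound 1 to compound 4 (the limit leaves the size open). Compound 4 is therefore estimated at 10000 nM, within a range from 3000 nM to 30000 nM.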

Compound 4, half-maximal effective concentration: 430 nM
Compound 4: the middle estimate sits 23-fold (1.37 log units) above what was measured; the measured number lies below the stated range.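

No size can be read for the step between compound 1 and compound 4, because the value of compound 1 is a limit and not a number: the limit of <= 10000 nM in this assay, at which 1 of the 4 values shown sits. The compounds shown leave open how large the step for chloro in place of hydrogen is in this assay on the shared core.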